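Thiosemicarbazone amidines: ring swap on the thiocarbonyl carbon

The source may hold more compounds than are shown below. What is called first, only, known or untested is meant among the compounds shown, and "the series" means these compounds.

Compound 3 `N/C(=N\NC(=S)N1CCCCC1)c1ccccn1` gives 15.5% in a functional assay on HeLa cells (Homo sapiens) for cytotoxicity, read by MTT assay, with a stated time of 72 h, tested at 1 uM (a lower number here means less inhibition of growth, a higher number more inhibition of growth at the concentration tested), the lowest of the three numbers measured. Compound 2 `N/C(=N\NC(=S)N1CCSCC1)c1ccccn1` gives 25.1%, and the change a number 9.6 percentage points lower from compound 2 to compound 3 (within the scatter) lies within the scatter. Within the data shown here, compound 1 `N/C(=N\NC(=S)N1CCCC1)c1ccc(F)cn1` gives 62.8%; it differs from compound 3 in two places, so no single step is computed for that pair, and its two values show only a wide gap. The next member, compound 4 `N/C(=N\NC(=S)N1CCCC1)c1ccccn1`, carries pyrrolidin-1-yl in place of piperidin-1-yl on a thiocarbonyl carbon. Among the measured compounds shown here, the only measured step touching this position, the one from compound 2 to compound 3, was within the scatter, so for the swap to pyrrolidin-1-yl no move beyond the scatter is grounded in the data on its own; compound 1, which also carries pyrrolidin-1-yl, only hints at a higher number. Compound 4 is therefore expected near 30%, with a range of 10% to 58%, which means an estimated step of a number 14.5 percentage points higher from compound 3 to compound 4 (beyond the scatter).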

Compound 4, percent growth inhibition at one concentration: 24.7%
Beside the measured number, compound 4's estimate is 5.3 percentage points above it; the measured number falls inside the stated range.
By their numbers in this assay, from the lowest: compounds 3, 4 and 2 (each within the scatter of the next); then compound 1.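

Working notes on the thiocarbonyl ring: in this assay, the two new ring swaps (a number 9.2 percentage points higher from compound 3 to compound 4 (within the scatter)) and (a number 0.4 percentage points lower from compound 2 to compound 4 (within the scatter)) join the earlier step in lying within the scatter, so pyrrolidin-1-yl, piperidin-1-yl and thiomorpholin-4-yl are not told apart at this position. Among these compounds, with pyrrolidin-1-yl held constant, the single change of hydrogen in place of fluoro on an aromatic carbon gives a large step (a number 38.1 percentage points lower from compound 1 to compound 4 (beyond the scatter)), so the wide gap seen for compound 1 goes with the fluoro change and not with the ring on the thiocarbonyl carbon. No supporting data bear on the reason for either result.

On these data alone, whether the fluoro step carries over to the piperidin-1-yl or thiomorpholin-4-yl members remains open. Also open, as far as these compounds go, is how chloro on the aromatic carbon, or morpholin-4-yl or an open-chain dimethylamino group on the thiocarbonyl carbon, would read in this assay.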